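Amino to Hydroxy: Expected Effect on Cell Growth Inhibition

The compounds below may be only part of what the source reports. "The series", "measured", "known", "first", "only" and "open" are said of these compounds alone.

Compound 1, `COc1cc(-c2c(-c3ccc4cc[nH]c4c3)c(=O)c2=O)cc(OC)c1OC`: "not determined" (no result reported) in a functional assay on HCT-116 cells (Homo sapiens) for inhibition, read by MTT assay, with a stated time of 72 h; a higher number here means a weaker inhibitor, a lower number a stronger inhibitor
Compound 2, `COc1cc(-c2c(-c3ccc4[nH]ccc4c3)c(=O)c2=O)cc(OC)c1OC`: "not determined" (no result reported) in this assay
Compound 3, `COc1ccc(-c2c(-c3cc(OC)c(OC)c(OC)c3)c(=O)c2=O)cc1N`: 5 nM

Of the three compounds measured in this assay, only compound 3 comes with a number; the entries for compound 1 and compound 2 carry no result at all. Compound 3 therefore stands alone, and its value of 5 nM marks it as a strong inhibitor of these cells. Among the measured compounds shown here, since no other compound has a number, there is no measured step between any pair of compounds that could show how a single structural change shifts the result.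

The next compound, compound 4, `COc1ccc(-c2c(-c3cc(OC)c(OC)c(OC)c3)c(=O)c2=O)cc1O`, differs from compound 3 in exactly one place: hydroxy in place of amino on an aromatic carbon, ortho to a methoxy group and meta to a large group. Both the leaving and the entering group carry one hydrogen-bond donor and one hydrogen-bond acceptor, and no ring or charge is gained or lost.

For the measured compounds named here, with no measured step to lean on, the expectation for compound 4 is a step from compound 3 that stays within the usual scatter, a 1.4-fold higher number from compound 3 to compound 4 (0.15 log units; within the scatter). The estimated value for compound 4 in this assay is 7 nM, within a range from 2 nM to 25 nM.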

Compound 4, half-maximal inhibitory concentration: 5 nM
For compound 4 the middle estimate is 1.4-fold (0.15 log units) above the measured one, and the stated range covers the measured number.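

In this assay, among the compounds shown here, putting hydroxy in place of amino on this aromatic carbon gives no change at the digits printed from compound 3 to compound 4 (within the scatter), and this is the first measured step, where until now a single number stood alone. At this place, ortho to a methoxy group and meta to a large group, the cell read-out therefore does not separate the two groups: 3-amino-4-methoxyphenyl and 3-hydroxy-4-methoxyphenyl serve equally well here, and the strong inhibition seen with compound 3 survives the exchange of the nitrogen for an oxygen in compound 4. Nothing measured on these compounds speaks to why the two groups match.

For the compounds shown here, compound 1 and compound 2 carry no number, so no step that involves them can be read, and what their different shared-core partner does to cell growth stays unknown. From the compounds shown here alone, it also remains open whether this place tolerates any group or only ones like these two, since a methyl group, a fluorine atom or an acetamide at the same carbon could give a very different answer.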